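The source may report more compounds than this note shows. Statements on the series, on what has been measured and on what is new or still open speak of the compounds shown alone.

Compound 1 `CC(C)CN(Cc1ccc(N2CCN(S(C)(=O)=O)CC2)cc1)S(=O)(=O)Cc1ccccc1`: <= 1000 nM (a limit)
Compound 2 `CC(C)CN(Cc1ccc(N2CCN(CS(C)(=O)=O)CC2)cc1)S(=O)(=O)Cc1ccccc1`: <= 1000 nM (a limit)
Compound 3 `COC1CCN(c2ccc(CN(CC(C)C)S(=O)(=O)Cc3ccccc3)cc2)CC1`: <= 1000 nM (a limit)

In a physicochemical assay for solubility, in phosphate buffer, measured as kinetic solubility, with a stated time of 24 h, at pH 7.4 (on this read-out lower numbers stand for lower solubility and higher numbers for higher solubility), compound 3 stands at <= 1000 nM, which is a limit and not a number. It has company there: the limit of <= 1000 nM in this assay, at which 3 of the 3 values shown sit. Compound 4 `CC(=O)N1CCN(c2ccc(CN(CC(C)C)S(=O)(=O)Cc3ccccc3)cc2)CC1` keeps the shared core and carries 4-acetylpiperazin-1-yl in place of 4-methoxypiperidin-1-yl on an aromatic carbon.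

Two measured steps change this same group: a step that the two limits leave unreadable from compound 1 to compound 3 and a step that the two limits leave unreadable from compound 2 to compound 3. A third, a step that the two limits leave unreadable from compound 1 to compound 2, changes the group on the ring nitrogen. None of them offers a size to carry over, so no step beyond the usual scatter is expected in this assay, in either direction. The expected change is a number no lower from compound 3 to compound 4 (the limit leaves the size open). The expectation rests on compound 3 at <= 1000 nM, again a limit. For compound 4 the estimated value is 1000 nM, with an expected range from 400 nM to 3000 nM.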

Compound 4, solubility: <= 1000 nM
Compound 4 gave a limit, no number; the forecaster's own chance of this, stated with the estimate: 75%; the middle value sits exactly at the limit.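

Compound 4 gives <= 1000 nM in this assay, which is a limit and not a number. Among the compounds shown here, no step from compound 1, compound 2 or compound 3 to compound 4 can be read, because all four share one limit: the limit of <= 1000 nM in this assay, at which 4 of the 4 values shown sit. As far as these compounds go, the actual values of all four compounds, and so any difference made by swapping these groups, stay open.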